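Swapping a Fluorobenzyl Tail for a Nitrophenyl Tail

The compounds below may be only part of what the source reports. "The series", "measured", "known", "first", "only" and "open" are said of these compounds alone.

Three compounds have been measured in a functional assay on Ehrlich cells (Mus musculus) for cytotoxicity, read by MTT assay, with a stated time of 24 h; on this read-out lower numbers stand for stronger inhibition and higher numbers for weaker inhibition:

Compound 1 `Cn1nc(-c2nnc(SCCc3ccc(F)cc3)o2)cc1-c1ccc(C(F)(F)F)cc1` gives 29200 nM.
Compound 2 `Cn1nc(-c2nnc(SCc3cccc([N+](=O)[O-])c3)o2)cc1-c1ccc(C(F)(F)F)cc1` gives > 100000 nM, which is a limit of the assay and not a number.
Compound 3 `Cn1nc(-c2ccc(C(F)(F)F)cc2)cc1-c1nnc(SCCc2ccc(F)cc2)o1` gives 39500 nM.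

Compound 1 and compound 2 share one core and differ in a single place: 3-nitrophenyl in place of 4-fluorobenzyl on a saturated chain carbon bound to a sulfur. In this assay this change produced an at least 3.4-fold higher number from compound 1 to compound 2 (0.53 log units; beyond the scatter). The size of that step is known only as a lower bound because the limit of > 100000 nM in this assay, at which 1 of the 3 values shown sits, is where compound 2 sits.

Compound 3 is built from the same atoms as compound 1, joined differently; the difference between the two cores is not broken down here. In this assay the numbers of compound 1 and compound 3 lie within the usual scatter of each other, so neither can be called weaker or stronger than the other.

Compound 4 `Cn1nc(-c2ccc(C(F)(F)F)cc2)cc1-c1nnc(SCc2cccc([N+](=O)[O-])c2)o1` has not yet been measured. Among the measured compounds shown here, it differs from compound 3 by 3-nitrophenyl in place of 4-fluorobenzyl on a saturated chain carbon bound to a sulfur, which is the same change, made at the same place, as the one from compound 1 to compound 2. For compound 4 the expectation is therefore a step of comparable size, estimated as a 4.1-fold higher number from compound 3 to compound 4 (0.61 log units; beyond the scatter), resting on an at least 3.4-fold higher number from compound 1 to compound 2 (0.53 log units; beyond the scatter). Compound 4 is thus estimated to give 160000 nM in this assay, with a range expected from 60000 nM to 400000 nM, and a real chance that only a limit is reported.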

Compound 4, half-maximal inhibitory concentration: > 100000 nM
Compound 4: only a limit was reported (the forecaster's own chance of this, stated with the estimate: 65%); the middle value is on the limit's open side.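

In this assay compound 4 gives > 100000 nM, which is a limit of the assay and not a number. Carried over to the second core, the change gives an at least 2.5-fold higher number from compound 3 to compound 4 (0.40 log units; beyond the scatter), so on both cores shown, replacing the 4-fluorobenzyl with the 3-nitrophenyl leads to weaker inhibition by an amount beyond the usual scatter. This shows that the direction of the step held on these two cores, but it does not show that the size of the step carried over, and two cores are too few to make a rule for the whole series: the same change on two cores in this assay, an at least 3.4-fold higher number (0.53 log units; beyond the scatter) from compound 1 to compound 2 and an at least 2.5-fold higher number (0.40 log units; beyond the scatter) from compound 3 to compound 4; the limit leaves it open whether they differ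

The compounds shown do not separate the new ring group from the shorter chain, since 2-(4-fluorophenyl)ethyl and 3-nitrobenzyl differ in both at once, so a 2-(3-nitrophenyl)ethyl group, or an amine in place of the nitro group on the same chain, remains an open case. They also cannot say how much weaker the two nitro compounds really are, or whether the two cores differ once the nitro group is present, as the read-out stops for both at the same point: the limit of > 100000 nM in this assay, at which 2 of the 4 values shown sit.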